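Dithiocarbamate anilides: extending the acetyl of compound 3

A few compounds are considered here, and "the series" means these few. Any claim that something is new, unique, unknown or untested is made for them only; others in the source may bear on it.

Measured compounds:
- compound 1 `Cc1ccc(NC(=O)CSC(=S)N[C@H]2CCOC2=O)cc1` gives 33500 nM in a functional assay on MCF7 cells (Homo sapiens) for cytotoxicity, read by MTT assay, with a stated time of 72 h; a higher number here means a weaker inhibitor, a lower number a stronger inhibitor
- compound 2 `O=C(CSC(=S)N[C@H]1CCOC1=O)Nc1ccc(F)cc1` gives 5830 nM in this assay
- compound 3 `CC(=O)c1ccc(NC(=O)CSC(=S)N[C@H]2CCOC2=O)cc1` gives > 128000 nM in this assay

Compound 3 stands at the bottom of the three: its value in this assay is a limit of the assay and not a number, (the limit of > 128000 nM in this assay, at which 1 of the 3 values shown sits). The measured steps that reach it are an at least 3.8-fold higher number from compound 1 to compound 3 (0.58 log units; beyond the scatter) and an at least 21-fold higher number from compound 2 to compound 3 (1.34 log units; beyond the scatter); the remaining step, a 5.7-fold lower number from compound 1 to compound 2 (0.76 log units; beyond the scatter), concerns the two substituted anilides only.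

Compound 4 `O=C(CSC(=S)N[C@H]1CCOC1=O)Nc1ccc(C(=O)/C=C/c2ccccc2)cc1` is not yet measured. It differs from compound 3 by 2-phenylethenyl in place of methyl on a carbonyl carbon. Within the data shown here, none of the measured steps touches the carbonyl carbon of the acetyl; all three exchange the group on the aromatic carbon. No shown step therefore bears on this change, and the starting point itself is only a limit, so the size and direction of the step in this assay cannot be read from the shared core series.

Compound 4 is expected at 100000 nM, with a range from 20000 nM to 300000 nM, in this assay. That estimate means a step of an at least 1.2-fold lower number from compound 3 to compound 4 (0.10 log units; that floor lies within the scatter), which is expected to be no more than an uncertain guess, with a real chance that compound 4 again returns only a limit.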

Compound 4, half-maximal inhibitory concentration: 44300 nM
Estimate against measurement, compound 4: 2.3-fold (0.35 log units) above; the range from low to high includes it.
By their numbers in this assay, from the lowest: compound 2; then compounds 1 and 4 (each within the scatter of the next). At a limit, above all of these: compound 3.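

Placing 2-phenylethenyl on the carbonyl carbon, a site no earlier step touched, restores a measurable value in this assay, with an at least 2.8-fold lower number from compound 3 to compound 4 (0.46 log units; beyond the scatter) as the step. Going by these compounds, the value of compound 3 is a limit of the assay and not a number, so the true size of this step stays unknown: the limit of > 128000 nM in this assay, at which 1 of the 4 values shown sits. Read as a change on the aromatic carbon, the larger group does not reach fluoro, with a 7.6-fold higher number from compound 2 to compound 4 (0.88 log units; beyond the scatter), and cannot be told apart from methyl, with a 1.3-fold higher number from compound 1 to compound 4 (0.12 log units; within the scatter), so the extension lifts the acetyl anilide back to the level of the methyl anilide, while compound 2 remains the strongest of the four.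

The compounds shown leave open whether the change depends on the double bond or on the phenyl ring, which a saturated 2-phenylethyl or a plain phenyl on the carbonyl carbon would separate. Also open, on these data alone, is whether substituents on the new ring, such as a methoxy group, a fluoro or a dimethylamino group, would move the value towards that of compound 2.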